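Pyridyl piperazine dithiocarbamates: from compound 3 to compound 4

The source may report more compounds than this note shows. Statements on the series, on what has been measured and on what is new or still open speak of the compounds shown alone.

Compound 3 `Nc1ccccc1NC(=O)c1ccc(CSC(=S)N2CCN(c3ccncc3)CC2)cc1` gives in a functional assay on MGC-803 cells (Homo sapiens) for antiproliferative activity, read by CCK-8 assay, with a stated time of 72 h, tested at 8 uM (on this read-out lower numbers stand for a weaker effect and higher numbers for a stronger effect at the one concentration tested), a value of 87.1%, the highest of the three numbers recorded so far. Compound 2 `CC1CCN(C(=S)SCc2ccc(C(=O)Nc3ccccc3N)cc2)CC1` gives 81.9%, which lies within the scatter of compound 3. Among the compounds with values here, compound 1 `Nc1ccccc1NC(=O)c1ccc(CSC(=S)N2CCN(Cc3ccccn3)CC2)cc1` gives 65.2%, and the step of a number 21.9 percentage points higher from compound 1 to compound 3 (beyond the scatter) is the only single-point change recorded; it lies beyond the scatter.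

Compound 4 `Nc1ccccc1NC(=O)c1ccc(CSC(=S)N2CCN(c3cccnc3)CC2)cc1` is not yet measured. It differs from compound 3 by pyridin-3-yl in place of pyridin-4-yl on an amine nitrogen in a ring. Within the data shown here, no measured step moves the ring nitrogen within a pyridyl group attached directly to the piperazine nitrogen. Among the measured compounds shown here, the one step that touches this position, a number 21.9 percentage points higher from compound 1 to compound 3 (beyond the scatter), exchanges (pyridin-2-yl)methyl for pyridin-4-yl, a larger change than the present one, and the data give no guide to the direction of a shift between pyridin-4-yl and pyridin-3-yl. A step within the scatter is therefore expected, and compound 4 is estimated at 82% in this assay, with a range from 66% to 93%. The expected step of a number 5.1 percentage points lower from compound 3 to compound 4 (within the scatter) is not expected to exceed the usual scatter.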

Compound 4, a percentage reported as inhibition, at one concentration (the size of the read-out at that concentration, not a potency): 76.9%
Estimate against measurement, compound 4: 5.1 percentage points above; the range from low to high includes it.
By their numbers in this assay, from the lowest: compound 1; then compounds 4, 2 and 3 (each within the scatter of the next, the first and the last beyond it).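

In this assay this position proves sensitive to where the ring nitrogen sits, even though the atoms are unchanged: pyridin-3-yl in place of pyridin-4-yl gives a number 10.2 percentage points lower from compound 3 to compound 4 (beyond the scatter), with the same heavy atoms and hydrogen-bond counts in both groups. Pyridin-3-yl in place of (pyridin-2-yl)methyl gives a number 11.7 percentage points higher from compound 1 to compound 4 (beyond the scatter), so a rise over compound 1 is not confined to pyridin-4-yl. No measurement on hand accounts for the effect of moving the ring nitrogen.

The compounds shown leave open how pyridin-2-yl or a plain phenyl would read on the same amine nitrogen, and thus whether a ring nitrogen is needed there at all. They also leave open how (pyridin-4-yl)methyl or (pyridin-3-yl)methyl would compare with the directly attached groups.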